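The compounds below may be only part of what the source reports. "The series", "measured", "known", "first", "only" and "open" are said of these compounds alone.

Measured in a functional assay (strain AB) with Danio rerio as the target, read by microscopy, with a stated time of 1 h; a higher number here means that more compound is needed for the effect, a lower number that less compound is needed:
- compound 1 `CN1CCc2c(sc(NC(=O)Nc3ccc(Cl)cc3)c2C(N)=O)C1`: 4700 nM
- compound 2 `CC(C)(C)OC(=O)N1CCc2c(sc(NC(=O)Nc3ccc(Cl)cc3)c2C(N)=O)C1`: > 25000 nM
- compound 3 `CC(C)(C)OC(=O)CCN1CCc2c(sc(NC(=O)Nc3ccc(Cl)cc3)c2C(N)=O)C1`: 1100 nM

Compound 2 gives > 25000 nM, which is a limit of the assay and not a number. Compound 3 has the lower of the two true numbers at 1100 nM, and compound 1 has the higher at 4700 nM.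

The next compound is compound 4 `CCCN1CCc2c(sc(NC(=O)Nc3ccc(Cl)cc3)c2C(N)=O)C1`. Relative to compound 3, the change is methyl in place of tert-butoxycarbonyl on a saturated chain carbon, two bonds along the chain from an amine nitrogen in a ring.

Within the data shown here, no measured step makes this exact change. The closest guide is the modest 4.3-fold lower number from compound 1 to compound 3 (0.63 log units; beyond the scatter), which shows what the whole chain ending in tert-butoxycarbonyl does relative to methyl. The at least modest an at least 5.3-fold higher number from compound 1 to compound 2 (0.72 log units; beyond the scatter) and the large at least 22-fold lower number from compound 2 to compound 3 (1.35 log units; beyond the scatter) show that the same group gives opposite outcomes depending on where it sits in these three compounds. Compound 4 keeps the chain but loses the tert-butoxycarbonyl, so part of the gain in a 4.3-fold lower number from compound 1 to compound 3 (0.63 log units; beyond the scatter) is expected to be lost in this assay.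

A modest move to a higher number is expected, a 2.5-fold higher number from compound 3 to compound 4 (0.41 log units; beyond the scatter). For compound 4 the estimate is 2800 nM, with an expected range of 800 nM to 10000 nM.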

Compound 4, half-maximal effective concentration: 3500 nM
Estimate against measurement, compound 4: 1.3-fold (0.10 log units) below; the measured number falls inside the stated range.
By their numbers in this assay, from the lowest: compound 3; then compounds 4 and 1 (each within the scatter of the next). At a limit, above all of these: compound 2.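

In this assay, the tert-butoxycarbonyl end of the chain matters (a 3.2-fold higher number from compound 3 to compound 4 (0.50 log units; beyond the scatter)), so the lower number of compound 3 is not reached by the three-carbon length of the chain alone. Propyl on the amine nitrogen in a ring cannot be told apart from methyl (a 1.3-fold lower number from compound 1 to compound 4 (0.13 log units; within the scatter)), so among the plain chains shown, lengthening adds nothing that can be read beyond the scatter. Propyl in place of tert-butoxycarbonyl directly on that nitrogen also gives a lower number (an at least 7.1-fold lower number from compound 2 to compound 4 (0.85 log units; beyond the scatter)), although this step has only a bound on its size, as compound 2 stands at a limit: the limit of > 25000 nM in this assay, at which 1 of the 4 values shown sits.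

Still open, on these data alone, is whether a carboxylic acid, a methyl ester or a primary amide at the same chain end would keep the number of compound 3, and whether a longer chain ahead of the ester would shift it. Also open, as far as these compounds go, is whether a butyl or pentyl chain would separate from methyl, given that propyl does not.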